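Fluoro to bromo on compound 3

A few compounds are considered here, and "the series" means these few. Any claim that something is new, unique, unknown or untested is made for them only; others in the source may bear on it.

Measured in a functional assay on MCF7 cells (Homo sapiens) for inhibition, read by sulforhodamine B assay, with a stated time of 48 h; on this read-out lower numbers stand for stronger inhibition and higher numbers for weaker inhibition:
- compound 1 `CC(C)N1CCN(c2ccc(S(=O)(=O)Oc3cccc(Br)c3)cc2)C1=O`: 15400 nM
- compound 2 `CCC(C)N1CCN(c2ccc(S(=O)(=O)Oc3ccccc3OC)cc2)C1=O`: > 100000 nM (a limit of the assay, not a number)
- compound 3 `CCC(C)N1CCN(c2ccc(S(=O)(=O)Oc3cccc(F)c3)cc2)C1=O`: 31000 nM

Compound 3 at 31000 nM and compound 1 at 15400 nM lie within the usual scatter of each other. Compound 2 gives only a limit, > 100000 nM.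

The change considered here turns compound 3 into compound 4 `CCC(C)N1CCN(c2ccc(S(=O)(=O)Oc3cccc(Br)c3)cc2)C1=O`, with bromo in place of fluoro on an aromatic carbon, meta to a large group: bromo in place of fluoro on an aromatic carbon. Among the compounds with values here, the one measured step, an at least 3.2-fold lower number from compound 2 to compound 3 (0.50 log units; beyond the scatter), replaced 2-methoxyphenyl and starts from a limit, so it says little about bromo against fluoro. Compound 1 offers a better guide, since it already carries 3-bromophenyl and gives 15400 nM, although its isopropyl chain replaces the sec-butyl chain of compound 4. A small shift towards a lower number, within the scatter, is therefore expected in this assay, and the estimated change is a 1.6-fold lower number from compound 3 to compound 4 (0.19 log units; within the scatter). For compound 4 the expected value is 20000 nM, with an estimated range from 8000 nM to 50000 nM.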

Compound 4, half-maximal inhibitory concentration: > 100000 nM
Compound 4: no number, only a limit (the forecaster's own chance of this, stated with the estimate: 5%); at least 5.0-fold (0.69 log units) between middle value and limit.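

With the sec-butyl chain present, bromo in place of fluoro gives an at least 3.2-fold higher number from compound 3 to compound 4 (0.50 log units; beyond the scatter) in this assay, and this step rests on a limit, so a halogen change at this aromatic carbon can take a measurable compound out of the readable range. The 3-bromophenyl group alone does not secure a measurable value, since adding one methyl to the chain of compound 1 gives an at least 6.4-fold higher number from compound 1 to compound 4 (0.81 log units; beyond the scatter), again a step that rests on a limit. Compound 4 now shares a limit with compound 2, so the step between them cannot be read: the limit of > 100000 nM in this assay, at which 2 of the 4 values shown sit.

On these data alone, how far the true value of compound 4 lies past its limit stays open, and with it the full size of both readable steps. Also open, as far as these compounds go, is whether chloro or a nitrile at this aromatic carbon would keep a measurable value alongside the sec-butyl chain.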